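The compounds below may be only part of what the source reports. "The series", "measured", "known", "first", "only" and "open" are said of these compounds alone.

Within the data shown here, in a functional assay on CHO-K1 cells with Glucose-dependent insulinotropic receptor (Homo sapiens) as the target, read by a luciferase reporter, with a stated time of 5 h (a higher number here means a larger maximal response, a lower number a smaller maximal response), compound 1 `CC(C)OC(=O)N1CCC(Oc2ncnc3c2CCN3c2ccc(S(C)(=O)=O)cc2)CC1` gives 154%, the highest of the three numbers measured so far, while compound 2 `CCCOC(=O)N1CCC(Oc2ncnc3c2CCN3c2ccc(S(C)(=O)=O)cc2F)CC1` gives 111% and compound 3 `CN(C)S(=O)(=O)N1CCC(Oc2ncnc3c2CCN3c2ccc(S(C)(=O)=O)cc2F)CC1` gives 68%. Among the measured compounds shown here, the only step between two compounds that differ in a single place is a number 43 percentage points lower from compound 2 to compound 3 (beyond the scatter); it alters the group on the amine nitrogen in the ring and leaves the aryl group on the core untouched. Compound 4 `CC(C)OC(=O)N1CCC(Oc2ncnc3c2CCN3c2ccc(S(C)(=O)=O)nc2)CC1` differs from compound 1 by 6-(methylsulfonyl)pyridin-3-yl in place of 4-(methylsulfonyl)phenyl on a nitrogen on an aromatic ring in a ring. For the measured compounds named here, no measured step bears on this change, so there is no direct footing for it, and the reading is held as open. Compound 4 is expected to give 130%, with a range from 90% to 165%. Against compound 1 this estimate means an expected a number 24 percentage points lower from compound 1 to compound 4 (beyond the scatter).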

Compound 4, largest response reached (reported as percent of maximum), in percent of the reference or control that the assay uses: 97%
The estimate for compound 4 lay 33 percentage points above the measured number; the range from low to high includes it.
By their numbers in this assay, from the lowest: compound 3; then compound 4; then compound 2; then compound 1.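

In this assay, the aryl group on the core, which the earlier step left untouched, now has a measured step of its own: 6-(methylsulfonyl)pyridin-3-yl in place of 4-(methylsulfonyl)phenyl gives a number 57 percentage points lower from compound 1 to compound 4 (beyond the scatter) and is large, so one ring nitrogen at this place changes the maximal response beyond the scatter. Nothing available accounts for this step. From the compounds shown here alone, whether the same change would carry over with propoxycarbonyl or dimethylsulfamoyl on the ring amine remains open, as does how a pyrimidine ring or a nitrile-bearing phenyl ring would read at this place.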